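The compounds below may be only part of what the source reports. "The series", "measured", "known", "first", "only" and "open" are said of these compounds alone.

Measured so far:
Compound 1 `COc1ccc(C2=NO[C@]3(C2)C(=O)O[C@@H]2[C@H]3CC[C@H](C)[C@]3(O)C=CC(=O)[C@@]23C)cc1`: 35000 nM
Compound 2 `C[C@H]1CC[C@@H]2[C@@H](OC(=O)[C@]23CC(c2cccc([N+](=O)[O-])c2)=NO3)[C@]2(C)C(=O)C=C[C@@]12O`: 55000 nM

In a functional assay on PC-3 cells (Homo sapiens) for cytotoxicity, read by sulforhodamine B assay, with a stated time of 48 h (a higher number here means a weaker inhibitor, a lower number a stronger inhibitor), compound 2, at 55000 nM, stands level with compound 1 within the scatter. Compound 3 `Cc1ccccc1C1=NO[C@]2(C1)C(=O)O[C@@H]1[C@H]2CC[C@H](C)[C@]2(O)C=CC(=O)[C@@]12C` has 2-methylphenyl in place of 3-nitrophenyl on a carbon with a double bond to nitrogen. Among the compounds with values here, only one measured step bears on this change: 3-nitrophenyl in place of 4-methoxyphenyl at the same carbon gave a 1.6-fold higher number from compound 1 to compound 2 (0.20 log units; within the scatter). Within the data shown here, no measured compound carries 2-methylphenyl, so this single step is a thin guide. It gives no reason to expect a change beyond the scatter in this assay, in either direction. The expected step is a 1.2-fold lower number from compound 2 to compound 3 (0.09 log units; within the scatter). Compound 3 is estimated at 45000 nM, with an expected range from 20000 nM to 90000 nM.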

Compound 3, half-maximal inhibitory concentration: 10000 nM
Beside the measured number, compound 3's estimate is 4.5-fold (0.65 log units) above it; the measured number lies below the stated range.
By their numbers in this assay, from the lowest: compound 3; then compounds 1 and 2 (each within the scatter of the next).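

In this assay, the group on the carbon with a double bond to nitrogen can move the number beyond the scatter: 2-methylphenyl gives a 5.5-fold lower number from compound 2 to compound 3 (0.74 log units; beyond the scatter) and a 3.5-fold lower number from compound 1 to compound 3 (0.54 log units; beyond the scatter). The earlier step between 4-methoxyphenyl and 3-nitrophenyl stayed within the scatter, so it gave no sign that a change at this carbon could matter. Both new steps are modest, but they place compound 3 lowest of the three, with a clear gap to each of the other two.

The compounds shown leave open whether the methyl group itself or its place on the ring goes with the lower number, and how an unsubstituted phenyl, 4-methylphenyl or an aminophenyl would compare. Nothing shown offers an explanation for the difference.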